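The compounds below may be only part of what the source reports. "The series", "measured", "known", "first", "only" and "open" are said of these compounds alone.

Measured so far in an ADME assay (liver) for metabolic stability, with Liver microsome (Rattus norvegicus) as the target, using microsomes and NADPH, with a stated time of 30 min, tested at 1 uM; a lower number here means slower removal, a higher number faster removal of the compound
compound 1 `Nc1ccc(S(=O)(=O)N2CCN(c3ncc(C(O)(C(F)(F)F)C(F)(F)F)cc3C#CCO)CC2)cn1` gives 65 mL.min-1.g-1
compound 2 `Nc1ccc(S(=O)(=O)N2CCN(c3ncc(C(O)(C(F)(F)F)C(F)(F)F)cc3-c3ccc4scnc4c3)CC2)cn1` gives 147 mL.min-1.g-1

Of the two, compound 2 holds the higher number, and at 147 mL.min-1.g-1 it stands beyond the scatter of compound 1. The next compound, compound 3 `Nc1ccc(S(=O)(=O)N2CCN(c3ncc(C(O)(C(F)(F)F)C(F)(F)F)cc3-c3cccc4[nH]ncc34)CC2)cn1` is reached from it by one change at a single place: 1H-indazol-4-yl in place of 1,3-benzothiazol-5-yl on an aromatic carbon here 1H-indazol-4-yl takes the place of 1,3-benzothiazol-5-yl on an aromatic carbon, ortho to a large group.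

For the measured compounds named here, only one measured step bears on this place, a 2.3-fold higher number from compound 1 to compound 2 (0.35 log units; beyond the scatter) which is modest and brought in 1,3-benzothiazol-5-yl in place of 3-hydroxyprop-1-yn-1-yl. That exchange replaced a chain with two fused rings. Going by the values given here, the present one keeps a five-membered aromatic ring with 2 hetero atoms and a six-membered aromatic ring of carbon only, so a smaller step is expected in this assay and the data hold no direct example of it. A slight fall is the tentative expectation, a 1.3-fold lower number from compound 2 to compound 3 (0.11 log units; within the scatter) and it may well stay within the scatter. For compound 3 the estimated value is 115 mL.min-1.g-1 (60 mL.min-1.g-1 to 210 mL.min-1.g-1).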

Compound 3, intrinsic clearance in microsomes: 93 mL.min-1.g-1
The estimate for compound 3 lay 1.2-fold (0.09 log units) above the measured number; low and high end bracket the measured number.
By their numbers in this assay, from the lowest: compounds 1, 3 and 2 (each within the scatter of the next, the first and the last beyond it).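

In this assay, replacing 1,3-benzothiazol-5-yl with 1H-indazol-4-yl on this aromatic carbon, ortho to a large group, gives a 1.6-fold lower number from compound 2 to compound 3 (0.20 log units; within the scatter) and so does not separate these two groups, although each has one five-membered aromatic ring with 2 hetero atoms and one six-membered aromatic ring of carbon only, and they differ in their counts of hydrogen-bond donors and acceptors. The other new comparison, a 1.4-fold higher number from compound 1 to compound 3 (0.16 log units; within the scatter), adds something the first pair could not show: compound 2 stood beyond the scatter of compound 1, but compound 3 does not, so a two-ring aromatic group at this place does not by itself set a compound apart from the 3-hydroxyprop-1-yn-1-yl compound. No measurement here explains these numbers.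

The compounds shown leave open whether the same holds for a single phenyl ring, or for an indazole attached through another ring carbon, such as 1H-indazol-5-yl. They also leave open how this assay responds at this carbon to a morpholine, an aliphatic amine or a carboxylic acid.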